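Aryloxyacetamide series: chromatographic lipophilicity, compound 3 to compound 4

This account rests on a few compounds, and the source may have more. Where it says the series, first, only, none or still open, it means among the compounds named here.

Among the measured compounds shown here, the three measured members share one core. Compound 1 `Cc1cc(C)cc(NC(=O)COc2cc(C)nc3ccc(C)cc23)c1` gives 5.95 in a physicochemical assay for lipophilicity, read by HPLC, in phosphate buffer, measured as chromatographic lipophilicity, at pH 7.4 (on this read-out lower numbers stand for lower lipophilicity and higher numbers for higher lipophilicity), compound 2 `CCCc1cc(OCC(=O)Nc2cc(C)cc(C)c2)c2cc(OC)ccc2n1` gives 6.44, and compound 3 `COc1ccc(NC(=O)COc2cc(C)nc3ccc(OC)cc23)cc1` gives 4.22. On these numbers compound 3 stands lowest of the three; its nearest neighbour is compound 1, whose value lies higher by a gap beyond the scatter, and compound 2 lies furthest above it, again beyond the scatter.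

Compound 4 `COc1ccc2nc(C)cc(OCC(=O)Nc3noc(C)c3C)c2c1` is not yet measured. It differs from compound 3 in one place: 4,5-dimethyl-1,2-oxazol-3-yl in place of 4-methoxyphenyl on an amide-type nitrogen. For the measured compounds named here, no measured pair in the set shows this exchange, so the size of the step has to be expected rather than read off. The expectation is a decrease in this assay of moderate size, beyond the scatter but smaller than the gaps separating compound 3 from compound 1 and compound 2.

For compound 4 the estimated value in this assay is 3.7, with a range from 3.1 to 4.3. The estimated step of a number 0.52 log units lower from compound 3 to compound 4 (beyond the scatter) is expected to leave compound 4 as the lowest member of the series.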

Compound 4, distribution coefficient: 3.3
Compound 4: the middle estimate sits 0.40 log units above what was measured; the measured number falls inside the stated range.
By their numbers in this assay, from the lowest: compound 4; then compound 3; then compound 1; then compound 2.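

The position on the amide-type nitrogen now has a step that can be read: 4,5-dimethyl-1,2-oxazol-3-yl in place of 4-methoxyphenyl gives a number 0.92 log units lower from compound 3 to compound 4 (beyond the scatter) in this assay, with the rest of the structure unchanged. The earlier compounds shown here differ in more than one place, so their gaps could not be tied to this group alone, whereas this exchange by itself moves the read-out beyond the scatter. No measurement bears on why the number moves in this direction.

As far as these compounds go, a single exchange at one position sets no trend, and whether the step keeps its size with the other substituents on the shared core stays open. Also open, from the compounds shown here alone, is how a carboxylic acid, an amine or a longer alkyl chain on the same nitrogen would read in this assay.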